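A Methoxycarbonyl Group on the Phenylethyl Side Chain

The compounds below may be only part of what the source reports. "The series", "measured", "known", "first", "only" and "open" are said of these compounds alone.

Measured in a functional assay on HL-60 cells (Homo sapiens), with a stated time of 4 days; on this read-out higher numbers stand for weaker inhibition and lower numbers for stronger inhibition:
Compound 1 `CC(C)CNC(=O)c1[nH]cnc1C(=O)Nc1ccc(Cl)c(Cl)c1`: 7200 nM
Compound 2 `C[C@@H](NC(=O)c1[nH]cnc1C(=O)Nc1ccc(Cl)c(Cl)c1)c1ccccc1`: 5900 nM
Compound 3 `C[C@H](NC(=O)c1[nH]cnc1C(=O)Nc1ccc(Cl)c(Cl)c1)C(=O)OC(C)(C)C`: 2400 nM

Compound 2 belongs to the upper pair of this small set, and that pair cannot be separated: a 1.2-fold lower number from compound 1 to compound 2 (0.09 log units; within the scatter). Among the compounds with values here, the one clear gap from compound 2 is a 2.5-fold lower number from compound 2 to compound 3 (0.39 log units; beyond the scatter). Compound 4 `COC(=O)[C@@H](NC(=O)c1[nH]cnc1C(=O)Nc1ccc(Cl)c(Cl)c1)c1ccccc1` keeps the core of compound 2 and changes a single group: methoxycarbonyl in place of methyl on a saturated chain carbon bound to an amide-type nitrogen and an aromatic carbon. This places methoxycarbonyl in place of methyl on a saturated chain carbon bound to an amide-type nitrogen and an aromatic carbon.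

The closest guides are the two steps to compound 3, which carries 1-(tert-butoxycarbonyl)ethyl: a 2.5-fold lower number from compound 2 to compound 3 (0.39 log units; beyond the scatter) and a 3.0-fold lower number from compound 1 to compound 3 (0.48 log units; beyond the scatter). Both are modest. Within the data shown here, compound 3 has no phenyl group, however, so no measured compound shows the two groups together. A modest move to a lower number is therefore expected in this assay, though it may stay within the scatter. The expected step is a 2.0-fold lower number from compound 2 to compound 4 (0.29 log units; within the scatter). Compound 4 is estimated at 3000 nM, with an expected range of 1200 nM to 7000 nM.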

Compound 4, half-maximal inhibitory concentration: 6800 nM
For compound 4 the middle estimate is 2.3-fold (0.36 log units) below the measured one; the range from low to high includes it.
By their numbers in this assay, from the lowest: compound 3; then compounds 2, 4 and 1 (each within the scatter of the next).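

In this assay, methoxycarbonyl in place of methyl on a saturated chain carbon bound to an amide-type nitrogen and an aromatic carbon gives a 1.2-fold higher number from compound 2 to compound 4 (0.06 log units; within the scatter), so this position accepts the larger group, with its two hydrogen-bond acceptors, with no readable difference from methyl. An ester-bearing side chain therefore does not by itself bring the separation seen in the earlier step, a 2.5-fold lower number from compound 2 to compound 3 (0.39 log units; beyond the scatter), since compound 4 carries methoxycarbonyl and still cannot be told apart from compound 2. No available measurement bears on the reason for this result.

On these data alone, it remains open whether a carboxylic acid or a primary amide in place of methoxycarbonyl would behave the same way at this carbon. The compounds shown also leave open whether a tert-butoxycarbonyl group on this same carbon, alongside the phenyl group, would give a readable step from compound 2.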